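This account rests on a few compounds, and the source may have more. Where it says the series, first, only, none or still open, it means among the compounds named here.

Measured so far in a functional assay on HT-29 cells (Homo sapiens) for inhibition, read by sulforhodamine B assay, with a stated time of 48 h; on this read-out higher numbers stand for weaker inhibition of growth and lower numbers for stronger inhibition of growth:
Compound 1 `S=C(N/N=C/c1cccs1)Nc1ccc(Cl)cc1`: > 100000 nM, a limit.
Compound 2 `Cc1ccc(NC(=S)N/N=C/c2cccs2)cc1`: > 100000 nM, a limit.

Compound 2 stands only as a limit, without a number, and compound 1 is the same: the limit of > 100000 nM in this assay, at which 2 of the 2 values shown sit. Within the data shown here, the one measured step is a step that the two limits leave unreadable from compound 1 to compound 2, with methyl in place of chloro on an aromatic carbon. It gives no size to carry forward.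

The next change leads to compound 3 `COc1ccc(NC(=S)N/N=C/c2cccs2)cc1`, with methoxy in place of methyl on an aromatic carbon, para to a large group: methoxy in place of methyl on an aromatic carbon. Among the measured compounds shown here, with only that unreadable step to go on, no step beyond the scatter is expected in this assay, and no direction can be assigned. Another report of only a limit is the likeliest outcome.

The expected change is a number no higher from compound 2 to compound 3 (the limit leaves the size open).

For compound 3 the estimate is 100000 nM, with an expected range of 30000 nM to 200000 nM.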

Compound 3, concentration for 50% growth inhibition: > 100000 nM
Compound 3: no number, only a limit (the forecaster's own chance of this, stated with the estimate: 75%); the middle value lies on the limit itself.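

No new step can be read among compound 1, compound 2 and compound 3 in this assay, since each stands only as a limit: the limit of > 100000 nM in this assay, at which 3 of the 3 values shown sit.

The compounds shown leave open whether chloro, methyl and methoxy differ at all in this assay, as none of the three has a number.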